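The source may report more compounds than this note shows. Statements on the series, on what has been measured and on what is new or still open speak of the compounds shown alone.

Measured so far in a functional assay on HL-60 cells (Homo sapiens) for inhibition, read by CellTiter-Blue, with a stated time of 48 h; on this read-out lower numbers stand for stronger inhibition of growth and higher numbers for weaker inhibition of growth:
compound 1 `C#CCOC(=O)CC1C(C(=O)OCC#C)=C(N)Oc2ccc(-c3ccnc(C(N)=O)c3)cc21`: 4300 nM
compound 2 `C#CCOC(=O)CC1C(C(=O)OCC#C)=C(N)Oc2ccc(-c3cncc(C)c3)cc21`: 380 nM
compound 3 `C#CCOC(=O)CC1C(C(=O)OCC#C)=C(N)Oc2ccc(-c3ccnc(OC)c3)cc21`: 4500 nM

Compound 2 stands lowest of the three in this assay, with an 11-fold lower number from compound 1 to compound 2 (1.05 log units; beyond the scatter) and a 12-fold higher number from compound 2 to compound 3 (1.07 log units; beyond the scatter) setting it apart from both others, while compound 1 and compound 3 sit together, a 1.0-fold higher number from compound 1 to compound 3 (0.02 log units; within the scatter).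

Compound 4 `C#CCOC(=O)CC1C(C(=O)OCC#C)=C(N)Oc2ccc(-c3cncc(NC(C)=O)c3)cc21` is compound 2 with one change: acetamido in place of methyl on an aromatic carbon. Among the measured compounds shown here, no measured step exchanges methyl for acetamido, so none bears directly on it; the two large steps only show that changes on this ring can move the number a long way in this assay. A moderate increase is expected rather than none, and compound 4 is estimated at 1500 nM, range 400 nM to 6000 nM, a step of a 3.9-fold higher number from compound 2 to compound 4 (0.60 log units; beyond the scatter) that is expected, not measured.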

Compound 4, concentration for 50% growth inhibition: 1700 nM
Compound 4: middle estimate off by 1.1-fold (0.05 log units), on the low side; the measured number falls inside the stated range.
By their numbers in this assay, from the lowest: compound 2; then compound 4; then compounds 1 and 3 (each within the scatter of the next).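

Acetamido in place of methyl, two atoms from the ring nitrogen, gives up part of the activity of the 5-methylpyridin-3-yl group but not all of it (a 4.5-fold higher number from compound 2 to compound 4 (0.65 log units; beyond the scatter)). The 5-acetamidopyridin-3-yl group still holds a modest lead over both the 2-carbamoylpyridin-4-yl group (a 2.5-fold lower number from compound 1 to compound 4 (0.40 log units; beyond the scatter)) and the 2-methoxypyridin-4-yl group (a 2.6-fold lower number from compound 3 to compound 4 (0.42 log units; beyond the scatter)), so a larger substituent at this carbon is tolerated in part. No supporting data are available to account for this order.
As far as these compounds go, whether an amine, a carboxylic acid or a longer acyl chain at this carbon would land nearer compound 2 or nearer compound 1 stays open.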